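This account rests on a few compounds, and the source may have more. Where it says the series, first, only, none or still open, it means among the compounds named here.

Measured so far:
compound 1 `O=S(=O)(c1ccc(F)c(Cl)c1)N1CCCC(Cn2ccnc2)C1`: 14 nM
compound 2 `N#Cc1ccc(S(=O)(=O)N2CCCC(Cn3ccnc3)C2)c(Cl)c1`: 79 nM

In an assay on isolated protein for inhibition of Aromatase (Homo sapiens), read by fluorescence (on this read-out higher numbers stand for weaker inhibition and lower numbers for stronger inhibition), compound 1 stands at the lowest of the two numbers; compound 2 gives 79 nM, a higher number that lies beyond the scatter. Compound 3 `O=S(=O)(c1ccc(F)cc1)N1CCCC(Cn2ccnc2)C1` has not yet been measured. It differs from compound 1 in one place: hydrogen in place of chloro on an aromatic carbon. Among the measured compounds shown here, no measured pair shows this change, so its size is not known from the data; a moderate rise in this assay is expected, more than the scatter but short of the gap to compound 2. The step expected is a 2.9-fold higher number from compound 1 to compound 3 (0.46 log units; beyond the scatter). Compound 3 is accordingly estimated at 40 nM, within 12 nM to 130 nM.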

Compound 3, half-maximal inhibitory concentration: 51 nM
For compound 3 the middle estimate is 1.3-fold (0.11 log units) below the measured one, within the range that was stated.
By their numbers in this assay, from the lowest: compound 1; then compounds 3 and 2 (each within the scatter of the next).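

In this assay, hydrogen in place of chloro on an aromatic carbon, ortho to a fluoro group, gives a 3.6-fold higher number from compound 1 to compound 3 (0.56 log units; beyond the scatter) and so puts a first size on this change. The step is modest but beyond the scatter, so the chloro group at this position does register in the read-out. Nothing measured on these compounds accounts for the step.

As far as these compounds go, what a bromo, methyl or methoxy group on this carbon would give remains open. So does whether the step keeps its size when the fluoro group is replaced by another group.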